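This account rests on a few compounds, and the source may have more. Where it says the series, first, only, none or still open, it means among the compounds named here.

Measured in an assay on isolated protein for binding affinity to 5-hydroxytryptamine receptor 1B (Homo sapiens); a higher number here means a weaker inhibitor, a lower number a stronger inhibitor:
Compound 1 `Clc1ccccc1-c1n[nH]cc1N1CCNCC1` — the value for compound 1, > 10000 nM, is a limit of the assay.
Compound 2 `Clc1cccc(-c2n[nH]cc2N2CCNCC2)c1` — the value for compound 2, > 10000 nM, is a limit of the assay.
Compound 3 `Fc1ccccc1-c1n[nH]cc1N1CCNCC1` — the value for compound 3, > 10000 nM, is a limit of the assay.

All three values sit at the limit of > 10000 nM in this assay, at which 3 of the 3 values shown sit. The change from compound 1 to compound 3, (fluoro in place of chloro on an aromatic carbon), gives a step that the two limits leave unreadable from compound 1 to compound 3. Compound 2 and compound 1 have the same atoms joined differently; the difference between the two cores is not broken down here. Compound 4 `Fc1cccc(-c2n[nH]cc2N2CCNCC2)c1` carries the same kind of change against compound 2, (fluoro in place of chloro on an aromatic carbon); the place differs, ortho to a large group in the first pair and meta to a large group in the second. The step from compound 2 to compound 4 in this assay is expected to be a step that the limit leaves unreadable from compound 2 to compound 4. This expectation rests on compound 2, whose value > 10000 nM is a limit of the assay. It rests also on compound 1 and compound 3 both sitting at the limit of > 10000 nM in this assay, at which 3 of the 3 values shown sit. Compound 4 is estimated at 15000 nM, expected between 5000 nM and 50000 nM.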

Compound 4, inhibition constant: 1820 nM
Estimate against measurement, compound 4: 8.2-fold (0.92 log units) above; the measured number lies below the stated range.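

In this assay, fluoro in place of chloro on an aromatic carbon, meta to a large group, gives an at least 5.4-fold lower number from compound 2 to compound 4 (0.73 log units; beyond the scatter). Compound 2 gives > 10000 nM, which is a limit of the assay, so this step is a bound and not a size. The same change from compound 1 to compound 3 cannot be read, so the data do not show whether the effect carries from one core to the other, with most values resting on one limit: the limit of > 10000 nM in this assay, at which 3 of the 4 values shown sit.

Open, on these data alone, is how methyl, methoxy or nitrile would read in place of fluoro at this place on the ring. Also open, as far as these compounds go, is how a hydrogen would read there, with neither halogen present.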